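From Nitro to Methoxy at Compound 3

The source may report more compounds than this note shows. Statements on the series, on what has been measured and on what is new or still open speak of the compounds shown alone.

In a functional assay on MIA PaCa-2 cells (Homo sapiens) for antiproliferative activity, read by sulforhodamine B assay, with a stated time of 48 h (a lower number here means a stronger inhibitor, a higher number a weaker inhibitor), compound 3 (`COc1cc(OC)c2sc(-c3ccc(N/C=C\C(=O)c4cc(OC)c(OC)c([N+](=O)[O-])c4)c(C)c3)nc2c1`) gives 10400 nM. Compound 2 (`COc1cc(OC)c2sc(-c3ccc(N/C=C\C(=O)c4ccc(OC)c([N+](=O)[O-])c4)c(C)c3)nc2c1`) gives 13900 nM, within the scatter of compound 3, and compound 1 (`COc1cc(OC)c2sc(-c3ccc(N/C=C\C(=O)c4ccc(OC)c(O)c4)c(C)c3)nc2c1`) gives 22100 nM, a higher number beyond the scatter.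

Compound 4 (`COc1cc(OC)c2sc(-c3ccc(N/C=C\C(=O)c4cc(OC)c(OC)c(OC)c4)c(C)c3)nc2c1`) carries methoxy in place of nitro on an aromatic carbon. Among the compounds with values here, two measured steps bear on this change. Nitro in place of hydroxy gave a 1.6-fold lower number from compound 1 to compound 2 (0.20 log units; within the scatter), and an added methoxy gave a 1.3-fold lower number from compound 2 to compound 3 (0.13 log units; within the scatter). Within the data shown here, neither leaves the scatter, and no measured pair shows this exact exchange, so no shift beyond the scatter is expected in this assay. The expected step is a 1.2-fold lower number from compound 3 to compound 4 (0.06 log units; within the scatter). The estimated value for compound 4 is 9000 nM, with an expected range from 3000 nM to 27000 nM.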

Compound 4, half-maximal inhibitory concentration: 17000 nM
For compound 4 the middle estimate is 1.9-fold (0.28 log units) below the measured one; the range from low to high includes it.
By their numbers in this assay, from the lowest: compounds 3, 2, 4 and 1 (each within the scatter of the next, the first and the last beyond it).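

In this assay, within the data shown here, methoxy in place of nitro on this aromatic carbon, ortho to a methoxy group, gives a 1.6-fold higher number from compound 3 to compound 4 (0.21 log units; within the scatter) and so offers the first direct reading of this exchange. The same compound stays close to the two others with a different group on the carbonyl carbon: 3,4,5-trimethoxyphenyl gives a 1.2-fold higher number from compound 2 to compound 4 (0.09 log units; within the scatter) against 4-methoxy-3-nitrophenyl and a 1.3-fold lower number from compound 1 to compound 4 (0.11 log units; within the scatter) against 3-hydroxy-4-methoxyphenyl. No evidence is available to explain these small steps.

From the compounds shown here alone, whether an amine or a carboxylic acid on this aromatic carbon would give a step beyond the scatter remains open.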